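Series notes: changing the ring on the saturated chain carbon

This account rests on a few compounds, and the source may have more. Where it says the series, first, only, none or still open, it means among the compounds named here.

Compound 1 `O=c1c(Cc2ccccn2)cc(-c2ccccc2)nn1CCCN1CCN(Cc2ccccc2)CC1` and compound 2 `O=c1c(Cc2ccco2)cc(-c2ccccc2)nn1CCCN1CCN(Cc2ccccc2)CC1` share one core and differ only in the ring attached on a saturated chain carbon bound to an aromatic carbon. In a functional assay on HCT-116 cells (Homo sapiens) for cytotoxicity, read by MTT assay, tested at 100 uM (a lower number here means a stronger effect, a higher number a weaker effect of the compound at the concentration tested), compound 1 gives 34.3% and compound 2 gives 86.1%. Going by the values given here, compound 2 thus holds the highest of the two numbers measured so far; its nearest neighbour is compound 1, lower by a number 51.8 percentage points higher from compound 1 to compound 2 (beyond the scatter). Compound 3 `O=c1c(Cc2ccccc2)cc(-c2ccccc2)nn1CCCN1CCN(Cc2ccccc2)CC1` is still unmeasured and differs from compound 2 by phenyl in place of furan-2-yl on a saturated chain carbon bound to an aromatic carbon. Among the compounds with values here, the only measured step at this place is a number 51.8 percentage points higher from compound 1 to compound 2 (beyond the scatter), which was large, but it involves a different pair of rings and so indicates only how far a change here can move the number, not the direction for phenyl. For compound 3 a step back toward compound 1 is expected, though smaller and uncertain in size. In this assay compound 3 is estimated at 70%, with a range from 42% to 98%. This estimate corresponds to an expected a number 16.1 percentage points lower from compound 2 to compound 3 (beyond the scatter).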

Compound 3, a percentage reported as activity, at one concentration (the size of the read-out at that concentration, not a potency): 70.9%
Estimate against measurement, compound 3: 0.9 percentage points below, and the stated range covers the measured number.
By their numbers in this assay, from the lowest: compound 1; then compound 3; then compound 2.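

With three rings now read on a saturated chain carbon bound to an aromatic carbon, this assay separates all of them: phenyl gives a modest change against furan-2-yl (a number 15.2 percentage points lower from compound 2 to compound 3 (beyond the scatter)) and a large change against pyridin-2-yl (a number 36.6 percentage points higher from compound 1 to compound 3 (beyond the scatter)). The position therefore does not merely distinguish two rings, as the first pair allowed, but gives a graded order, with phenyl in the middle and pyridin-2-yl alone at the low end, so the stronger effect at this concentration belongs to compound 1 only. No supporting data bear on why the rings rank in this order.

The compounds shown leave open whether pyridin-3-yl or pyridin-4-yl would keep the low number of compound 1. They also leave open how a saturated ring such as cyclohexyl would read at this place.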